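A Methyl Branch on the Side Chain of Compound 1

A few compounds are considered here, and "the series" means these few. Any claim that something is new, unique, unknown or untested is made for them only; others in the source may bear on it.

Compound 1, `CCCNS(=O)(=O)c1ccc(Nc2ncc3c(n2)N(C2CCCC2)[C@H](CC)C(=O)N3C)cc1`, was tested in a functional assay on Huh-7 cells (Homo sapiens) for antiproliferative activity, read by CCK-8 assay, with a stated time of 72 h (a lower number here means a stronger inhibitor of growth, a higher number a weaker inhibitor of growth), and gave 278 nM. Compound 2, `CCCCNC(=O)c1ccc2c(ccn2-c2ncc3c(n2)N(C2CCCC2)[C@H](CC)C(=O)N3C)c1`, in this assay gave 683 nM. Of these two numbers, compound 1 has the lower one and so is the stronger growth inhibitor of the pair; its gap to compound 2 lies beyond the usual scatter of the measurement.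

Compound 3, `CC[C@@H]1C(=O)N(C)c2cnc(Nc3ccc(S(=O)(=O)NCC(C)C)cc3)nc2N1C1CCCC1`, has not yet been measured. It differs from compound 1 by methyl in place of hydrogen on a saturated chain carbon bound to two saturated chain carbons, which at one bond further out reads as propylamino becoming isobutylamino. Going by the values given here, no pair of measured compounds shows what this change does in this assay, so the direction cannot be read from the data. Such a small change is expected to give a step of a 1.1-fold lower number from compound 1 to compound 3 (0.03 log units; within the scatter), staying within the scatter. Compound 3 is therefore estimated at 260 nM, with a likely range from 120 nM to 560 nM.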

Compound 3, concentration for 50% growth inhibition: 411 nM
Compound 3: middle estimate off by 1.6-fold (0.20 log units), on the low side, and the stated range covers the measured number.
By their numbers in this assay, from the lowest: compounds 1, 3 and 2 (each within the scatter of the next, the first and the last beyond it).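

In this assay, the change from propylamino to isobutylamino gives a 1.5-fold higher number from compound 1 to compound 3 (0.17 log units; within the scatter), so this added methyl on a saturated chain carbon bound to two saturated chain carbons leaves compound 1 and compound 3 indistinguishable. This is the first pair shown that differs in one place, and it shows that this chain can carry a small methyl branch without a measurable change in growth inhibition. No available evidence bears on the reason for this result.

From the compounds shown here alone, what remains open is whether a longer chain, a ring such as cyclopropyl, or a chain ending in an amine or a carboxylic acid would also leave the number unmoved. Going by these compounds, it is also open whether the same methyl branch would give a similar step on the side chain of compound 2.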